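Adding a Methoxy to Compound 2

A few compounds are considered here, and "the series" means these few. Any claim that something is new, unique, unknown or untested is made for them only; others in the source may bear on it.

Compound 1 `COc1cccc2cc(CSc3nc4cncnc4n3[C@@H]3O[C@H](COC(C)=O)[C@@H](O)[C@H]3O)c(=O)oc12`: 11000 nM
Compound 2 `O=c1oc2ccccc2cc1CSc1nc2cncnc2n1[C@@H]1O[C@H](CO)[C@@H](O)[C@H]1O`: 50000 nM

Only these two compounds have been measured in a functional assay on Huh-5-2 cells (Homo sapiens) for cytotoxicity, read by microscopy; a higher number here means that more compound is tolerated, a lower number that less compound is tolerated. Compound 2 gives the higher number of the pair at 50000 nM, and compound 1 gives 11000 nM, a gap beyond the usual scatter. The next compound to be tested is compound 3 `COc1cccc2cc(CSc3nc4cncnc4n3[C@@H]3O[C@H](CO)[C@@H](O)[C@H]3O)c(=O)oc12`, which differs from compound 2 in one place: methoxy in place of hydrogen on an aromatic carbon. Among the measured compounds shown here, no measured pair differs in one place only, so the data do not show directly what this change does in this assay. For the measured compounds named here, the only guide is compound 1, which also bears a methoxy and gives 11000 nM. A small downward step is therefore expected, and the number for compound 3 is expected to stay within reach of both measured values. The expected change is a 2.0-fold lower number from compound 2 to compound 3 (0.30 log units; within the scatter). Compound 3 is estimated at 25000 nM, with an expected range from 10000 nM to 60000 nM.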

Compound 3, half-maximal cytotoxic concentration: 47000 nM
The estimate for compound 3 lay 1.9-fold (0.27 log units) below the measured number, within the range that was stated.
By their numbers in this assay, from the lowest: compound 1; then compounds 3 and 2 (each within the scatter of the next).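

In this assay, methoxy in place of hydrogen on an aromatic carbon, ortho to a fused ring and meta to a fused ring, gives a 1.1-fold lower number from compound 2 to compound 3 (0.03 log units; within the scatter), so compound 2 and compound 3 cannot be told apart in this read-out, and this carbon accepts the methoxy without a measurable shift. With the methoxy present on both compounds, hydrogen in place of acetyl on an oxygen on a saturated carbon gives a 4.3-fold higher number from compound 1 to compound 3 (0.63 log units; beyond the scatter), so among these compounds the only single-place step beyond the scatter lies at that oxygen and not on the aromatic carbon. Nothing measured alongside these numbers accounts for the size of either step.

As far as these compounds go, it remains open whether a different group on the same aromatic carbon, such as a chlorine atom, an amine or a longer ether chain, would leave the number just as unchanged. From the compounds shown here alone, it is also open whether the acetyl step would appear without the methoxy, and whether a longer ester, such as a butanoyl group, on that oxygen would give a step of similar size.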